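From chloro to ethoxycarbonyl: estimating compound 4

The compounds below may be only part of what the source reports. "The series", "measured", "known", "first", "only" and "open" are said of these compounds alone.

In a functional assay on HL-60 cells (Homo sapiens) for cytotoxicity, read by MTT assay (on this read-out higher numbers stand for weaker inhibition and lower numbers for stronger inhibition), compound 3 (`CC(NS(=O)(=O)c1ccc(Cl)cc1)C1=CC(=O)c2c(O)ccc(O)c2C1=O`) gives 250 nM as the highest number of the three, with compound 1 (`Cc1ccc(S(=O)(=O)NC(C)C2=CC(=O)c3c(O)ccc(O)c3C2=O)cc1`) at 30 nM and compound 2 (`COc1ccc(S(=O)(=O)NC(C)C2=CC(=O)c3c(O)ccc(O)c3C2=O)cc1`) at 20 nM within the scatter of each other. Compound 4 (`CCOC(=O)c1ccc(S(=O)(=O)NC(C)C2=CC(=O)c3c(O)ccc(O)c3C2=O)cc1`) carries ethoxycarbonyl in place of chloro on an aromatic carbon para to a large group. Among the compounds with values here, two measured steps bear on this change, namely an 8.3-fold higher number from compound 1 to compound 3 (0.92 log units; beyond the scatter) and a 13-fold higher number from compound 2 to compound 3 (1.10 log units; beyond the scatter) with chloro entering each time. Neither involves ethoxycarbonyl, so only a moderate move towards a lower number is expected. The step expected in this assay is therefore modest (a 2.8-fold lower number from compound 3 to compound 4 (0.44 log units; beyond the scatter)). Compound 4 is expected at 90 nM (estimated range 25 nM to 320 nM).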

Compound 4, half-maximal inhibitory concentration: 120 nM
Beside the measured number, compound 4's estimate is 1.3-fold (0.12 log units) below it; measured number inside the range.
By their numbers in this assay, from the lowest: compounds 2 and 1 (each within the scatter of the next); then compound 4; then compound 3.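

At this aromatic carbon, in this assay, ethoxycarbonyl gives back part of the loss seen with chloro, with a 2.1-fold lower number from compound 3 to compound 4 (0.32 log units; beyond the scatter). The recovery is only partial, since methyl and methoxy still give lower numbers, with a 4.0-fold higher number from compound 1 to compound 4 (0.60 log units; beyond the scatter) and a 6.0-fold higher number from compound 2 to compound 4 (0.78 log units; beyond the scatter). Nothing measured here accounts for this order among the four groups. Going by these compounds, whether a carboxylic acid or an amine at this carbon would sit nearer to methyl and methoxy or to chloro stays open, as does the effect of a longer ester chain.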